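Furan-3-yl for thiophen-2-yl on the imidazoline ether series

This account rests on a few compounds, and the source may have more. Where it says the series, first, only, none or still open, it means among the compounds named here.

Compound 2 `c1csc(-c2ccccc2OCC2=NCCN2)c1` carries thiophen-2-yl on the shared core, and in a functional assay for activation of Alpha-1D adrenergic receptor (Homo sapiens), read by calcium flux (on this read-out lower numbers stand for an effect already at smaller amounts and higher numbers for an effect only at larger amounts of compound), compound 2 gives 15.9 nM. Among the values shown this is the only measured number; the other entry is a limit. Compound 1 `c1ccc(-c2cnccn2)c(OCC2=NCCN2)c1` returns in this assay only a limit, < 100000 nM, and not a number, as recorded in the limit of < 100000 nM in this assay, at which 1 of the 2 values shown sits. The step that the limit leaves unreadable from compound 1 to compound 2 therefore has no readable size, though it runs towards compound 2 as the better of the pair.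

Compound 3 `c1ccc(-c2ccoc2)c(OCC2=NCCN2)c1` differs from compound 2 by furan-3-yl in place of thiophen-2-yl on an aromatic carbon. Among the measured compounds shown here, no measured step exchanges one five-membered aromatic ring for another, so none of the recorded steps bears directly on this change; the one step recorded starts from a six-membered ring and is unreadable. On paper the change is a small one, and the working expectation is a step of modest size, if any, towards larger amounts. For compound 3 the estimated value in this assay is 40 nM, with a range from 8 nM to 200 nM. The step expected is a 2.5-fold higher number from compound 2 to compound 3 (0.40 log units; beyond the scatter).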

Compound 3, half-maximal effective concentration: 5.01 nM
Beside the measured number, compound 3's estimate is 8.0-fold (0.90 log units) above it; the measured number lies below the stated range.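

In this assay, among the compounds shown here, furan-3-yl in place of thiophen-2-yl on an aromatic carbon gives a 3.2-fold lower number from compound 2 to compound 3 (0.50 log units; beyond the scatter), the first step at this position with a readable size. The two groups match in heavy atom count, in hydrogen-bond acceptors and in being five-membered aromatic rings with 1 hetero atom, yet the step still lies beyond the scatter, so a match in these counts does not make the two groups equivalent here. Compound 2 and compound 3 both give measured numbers, while the steps from compound 1 to each of them cannot be read because compound 1 returns only a limit and not a number: the limit of < 100000 nM in this assay, at which 1 of the 3 values shown sits.

In this step, oxygen replaces sulfur and the point of attachment changes at the same time, and the compounds shown do not separate the two changes; furan-2-yl or thiophen-3-yl on the same carbon would bear on that question. Also open, as far as these compounds go, is where a plain phenyl ring, or a five-membered ring carrying an amine, would fall in this assay relative to thiophen-2-yl, furan-3-yl and pyrazin-2-yl.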